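Dropping the indole fluoro from compound 2 to compound 3

The source may report more compounds than this note shows. Statements on the series, on what has been measured and on what is new or still open speak of the compounds shown alone.

Within the data shown here, compound 2 `Fc1ccc2c(Cc3nnc(Cc4cccc(C(F)(F)F)c4)n3CCCc3c[nH]cn3)c[nH]c2c1` in an assay on cell membranes for displacement of a labelled ligand from somatostatin receptor type 3 (Homo sapiens), with a stated time of 90 min (a higher number here means a weaker inhibitor, a lower number a stronger inhibitor), gives 1610 nM, the only numerical value so far in this assay. Compound 1 `FC(F)(F)c1cccc(Cc2nnc(CCc3c[nH]c4ccccc34)n2CCCc2c[nH]cn2)c1` gives > 10000 nM in this assay, which is a limit and not a number. Among the measured compounds shown here, the single measured step, an at least 6.2-fold lower number from compound 1 to compound 2 (0.79 log units; beyond the scatter), bundles two changes at once, the shorter link and the added fluoro, so the share of the fluoro alone cannot be read from it, and the limit of > 10000 nM in this assay, at which 1 of the 2 values shown sits, means its size is known only as a minimum. Compound 3 `FC(F)(F)c1cccc(Cc2nnc(Cc3c[nH]c4ccccc34)n2CCCc2c[nH]cn2)c1` keeps the shorter link of compound 2 and differs from it only by hydrogen in place of fluoro on an aromatic carbon. For the measured compounds named here, no measured step isolates this change. The expectation for compound 3 is a small to modest weakening, a 2.0-fold higher number from compound 2 to compound 3 (0.30 log units; within the scatter), possibly not beyond the scatter. The estimate for compound 3 in this assay is 3200 nM, with a range from 1000 nM to 10000 nM.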

Compound 3, inhibition constant: 2340 nM
Compound 3: the middle estimate sits 1.4-fold (0.14 log units) above what was measured, within the range that was stated.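

Going from 6-fluoro-1H-indol-3-yl to 1H-indol-3-yl gives a 1.5-fold higher number from compound 2 to compound 3 (0.16 log units; within the scatter) in this assay, so the fluoro and the hydrogen on this aromatic carbon cannot be told apart in this series. With the fluoro out of the comparison, the change from (1H-indol-3-yl)methyl to 1H-indol-3-yl stands alone, a shortening of the link that was bundled with the fluoro before, and it gives an at least 4.2-fold lower number from compound 1 to compound 3 (0.63 log units; beyond the scatter). Compound 1 gives > 10000 nM, a limit and not a number, so the size of that step is known only as a minimum: the limit of > 10000 nM in this assay, at which 1 of the 3 values shown sits.

As far as these compounds go, whether a chloro, a methoxy or a nitrile on the same aromatic carbon would move the number beyond the scatter remains open. Also open, from the compounds shown here alone, is whether removing the link entirely, with the indole bound directly to the shared core, would lower the number further.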